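Adding trifluoromethoxy to compound 2

This account rests on a few compounds, and the source may have more. Where it says the series, first, only, none or still open, it means among the compounds named here.

In a physicochemical assay for solubility, in phosphate buffer, with a stated time of 18 h, at pH 7.4 (on this read-out lower numbers stand for lower solubility and higher numbers for higher solubility), compound 1 (`Nc1nc(-c2ccccc2)nn1-c1ncnc2ccccc12`) gives 1000 nM, compound 2 (`Nc1nc(-c2ccccn2)nn1-c1ncnc2ccccc12`) gives 9000 nM, and compound 3 (`COc1ccc2ncnc(-n3nc(-c4ccccn4)nc3N)c2c1`) gives 7000 nM. Compound 2 thus stands level with compound 3 within the scatter and clearly apart from compound 1. Compound 4 (`Nc1nc(-c2ccccn2)nn1-c1ncnc2cc(OC(F)(F)F)ccc12`) has trifluoromethoxy in place of hydrogen on an aromatic carbon of compound 2: trifluoromethoxy in place of hydrogen on an aromatic carbon. Swapping phenyl for pyridin-2-yl gave a 9.0-fold higher number from compound 1 to compound 2 (0.95 log units; beyond the scatter), but that change is not repeated here. The closest guide is methoxy in place of hydrogen on an aromatic carbon, which gave a 1.3-fold lower number from compound 2 to compound 3 (0.11 log units; within the scatter). A small downward step, if any, is therefore expected: a 1.8-fold lower number from compound 2 to compound 4 (0.26 log units; within the scatter). Compound 4 is estimated at 5000 nM, with an expected range of 1500 nM to 12000 nM.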

Compound 4, solubility: 3000 nM
Beside the measured number, compound 4's estimate is 1.7-fold (0.22 log units) above it; low and high end bracket the measured number.
By their numbers in this assay, from the lowest: compound 1; then compound 4; then compounds 3 and 2 (each within the scatter of the next).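

In this assay trifluoromethoxy on this carbon of the shared core gives (a 3.0-fold lower number from compound 2 to compound 4 (0.48 log units; beyond the scatter)), so a substituent on this ring can move the number beyond the scatter. Methoxy, on another carbon of the same ring, gave only (a 1.3-fold lower number from compound 2 to compound 3 (0.11 log units; within the scatter)). Nothing available explains the difference between these two steps. The compounds shown leave open whether the larger step belongs to the group or to the carbon it sits on, and how an amine or a carboxylic acid on this carbon would read.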